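A few compounds are considered here, and "the series" means these few. Any claim that something is new, unique, unknown or untested is made for them only; others in the source may bear on it.

Measured compounds in an assay for inhibition of Dihydrofolate reductase (Homo sapiens); on this read-out lower numbers stand for lower potency and higher numbers for higher potency (the scale is a negative logarithm):
- compound 1, `Nc1nc(S)c2cc(S(=O)(=O)c3ccc4ccccc4c3)ccc2n1`, gives 7.6
- compound 2, `Nc1nc(O)c2cc(S(=O)(=O)c3ccc4ccccc4c3)ccc2n1`, gives 7.96
- compound 3, `Nc1nc(O)nc2ccc(Sc3ccc4ccccc4c3)cc12`, gives 5.77

Compound 2 and compound 1 share one core and differ in a single place: sulfanyl in place of hydroxy on an aromatic carbon. That change gives a number 0.36 log units lower from compound 2 to compound 1 (beyond the scatter), a step told as beyond the scatter.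

Compound 3 stands on a different core; how its core differs from that of compound 2 is not broken down here. What the two values show is that compound 3 lies well under both compound 1 and compound 2 in this assay.

Compound 4, `Nc1nc(S)nc2ccc(Sc3ccc4ccccc4c3)cc12`, is not yet measured. It differs from compound 3 in one place: sulfanyl in place of hydroxy on an aromatic carbon. Going by the values given here, this is the same kind of change as the one from compound 2 to compound 1, though the surroundings are not the same word for word: in compound 1 the sulfanyl sits next to the ring nitrogen, ortho to a fused ring and opposite the ring nitrogen, while in compound 4 it sits between two ring nitrogen atoms and para to a fused ring.

Among the compounds with values here, only one example of this change is measured, so the expectation rests on a single step. Compound 4 is expected to move relative to compound 3 by about a number 0.37 log units lower from compound 3 to compound 4 (beyond the scatter), a step of about the size seen in a number 0.36 log units lower from compound 2 to compound 1 (beyond the scatter). On that basis the estimate for compound 4 in this assay is 5.4, with a likely span from 4.9 to 5.9.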

Compound 4, logarithm of the reciprocal of the active concentration, log(1/C): 5.52
The estimate for compound 4 lay 0.12 log units below the measured number, within the range that was stated.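

In this assay, sulfanyl in place of hydroxy on an aromatic carbon can now be read on two cores, and the two steps do not differ in size: the same change on two cores in this assay, a number 0.36 log units lower (beyond the scatter) from compound 2 to compound 1 and a number 0.25 log units lower (within the scatter) from compound 3 to compound 4, 0.11 log units apart, within the scatter of two such steps. Read alone, the earlier step is a number 0.36 log units lower from compound 2 to compound 1 (beyond the scatter), while the new one is a number 0.25 log units lower from compound 3 to compound 4 (within the scatter); compound 3 and compound 4 therefore cannot be separated on their core. Going by these compounds alone, this agreement supports using the step from one of these cores as a rough guide for the other, but it rests on only two pairs: it does not show that the change would carry to a third core, or that sulfanyl lowers the number on the core of compound 3.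

The compounds shown carry only hydroxy or sulfanyl at this place, leaving open how an amine or a methoxy group there would read on either core. From the compounds shown here alone, it also remains open whether the two steps would still agree if the surroundings of this place were altered, for example with a carboxylic acid or a longer chain elsewhere on the core.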